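Trifluoromethoxy in Place of Chloro on the Sulfonyl Aryl

A few compounds are considered here, and "the series" means these few. Any claim that something is new, unique, unknown or untested is made for them only; others in the source may bear on it.

Compound 3 `O=C(/C=C/c1ccccc1)c1ccc(N2CCN(S(=O)(=O)c3ccc(Cl)cc3)CC2)cc1` stands second highest of the three numbers in a functional assay on the whole organism (strain Kunming) for inhibition, with Mus musculus as the target, with a stated time of 1 h, at a dose of 40 mg/kg by the oral route; a lower number here means less inhibition, a higher number more inhibition at the dose given (going by the name of the read-out): compound 3 gives 46.8%. Its nearest neighbour is compound 2 `O=C(/C=C/c1ccc(Cl)cc1)c1ccc(N2CCN(S(=O)(=O)c3ccc(Cl)cc3)CC2)cc1`, which in this assay gives 56.6%, so that the step of a number 9.8 percentage points lower from compound 2 to compound 3 (within the scatter) is one that cannot be told from repeat measurement. The furthest is compound 1 `Cc1ccc(N2CCN(c3ccc(C(=O)/C=C/c4ccccc4)cc3)CC2)cc1`, which in this assay gives 2.85%, and the step of a number 44 percentage points higher from compound 1 to compound 3 (beyond the scatter) is the only large one among the three compounds.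

Compound 4 `O=C(/C=C/c1ccccc1)c1ccc(N2CCN(S(=O)(=O)c3ccc(OC(F)(F)F)cc3)CC2)cc1` differs from compound 3 in a single respect: trifluoromethoxy in place of chloro on an aromatic carbon. For the measured compounds named here, two measured steps bear on this change, though neither probes it directly. The step of a number 44 percentage points higher from compound 1 to compound 3 (beyond the scatter) shows that the whole group on the amine nitrogen matters greatly, but it exchanges the entire group, not a substituent on it. The step of a number 9.8 percentage points lower from compound 2 to compound 3 (within the scatter) exchanges a chloro for hydrogen on the other aromatic ring and stays within the scatter. The exchange of one aromatic substituent for another is therefore expected to move this assay little, with no step beyond the scatter in either direction. For compound 4 the expected step is a number 0.8 percentage points lower from compound 3 to compound 4 (within the scatter), and compound 4 is estimated at 46%, within a range of 26% to 66%.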

Compound 4, a percentage reported as inhibition, in the whole organism at one dose (the size of the read-out at that dose, not a potency): 47.4%
The estimate for compound 4 lay 1.4 percentage points below the measured number; the range from low to high includes it.
By their numbers in this assay, from the lowest: compound 1; then compounds 3, 4 and 2 (each within the scatter of the next).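

In this assay, for the compounds shown here, the step of a number 0.6 percentage points higher from compound 3 to compound 4 (within the scatter) is the first measured exchange of one substituent for another on the aryl ring of the sulfonyl group, since the earlier large step replaced the whole group on the amine nitrogen. It shows that at this place, on an aromatic carbon para to a large group, chloro with its single heavy atom and trifluoromethoxy with five heavy atoms and one hydrogen-bond acceptor cannot be told apart in this read-out. The high number seen with the 4-chlorophenyl group therefore does not depend on chloro alone, as 4-(trifluoromethoxy)phenyl serves equally well at this dose, and no measurement at hand accounts for the two groups reading alike.

Still open, as far as these compounds go, is whether a group of a different kind at this place, such as an amine, a carboxylic acid or a longer alkyl chain, would keep the number level with those of compound 3 and compound 4. Also open, from the compounds shown here alone, is whether trifluoromethoxy would read the same alongside the chloro that compound 2 carries on its other aromatic ring, and how these compounds would compare at other doses.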